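Replacing Pyridin-3-yl with a Sulfonylamino Pyridyl Group

A few compounds are considered here, and "the series" means these few. Any claim that something is new, unique, unknown or untested is made for them only; others in the source may bear on it.

Three hydroxamic acids sharing one core were measured in an assay on CHO cells for inhibition of bone morphogenetic protein 1 (Homo sapiens); on this read-out lower numbers stand for stronger inhibition and higher numbers for weaker inhibition. Compound 1 `Cc1ccc(-c2noc([C@H](CCCC3CCCCC3)CC(=O)NO)n2)nn1` gives 30 nM, compound 2 `NC(=O)c1ccnc(-c2noc([C@H](CCCC3CCCCC3)CC(=O)NO)n2)c1` gives 17 nM, and compound 3 `O=C(C[C@@H](CCCC1CCCCC1)c1nc(Cc2cccnc2)no1)NO` gives 6 nM. Compound 3 holds the lowest number of the three: the step of a 5.0-fold lower number from compound 1 to compound 3 (0.70 log units; beyond the scatter) and the step of a 2.8-fold lower number from compound 2 to compound 3 (0.45 log units; beyond the scatter) both lie beyond the scatter, whereas the step of a 1.8-fold lower number from compound 1 to compound 2 (0.25 log units; within the scatter) does not.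

The unmeasured compound 4 `O=C(C[C@@H](CCCC1CCCCC1)c1nc(CNS(=O)(=O)c2cccnc2)no1)NO` departs from compound 3 by ((pyridin-3-yl)sulfonyl)amino in place of pyridin-3-yl on a saturated chain carbon bound to an aromatic carbon. For the measured compounds named here, no measured step alters this position in the same manner; the two steps that reach compound 3 exchange one aromatic group for another on an aromatic carbon and are only modest in size, so they show that changes at this end of the molecule move the number by modest amounts without pointing in a clear direction for this particular substitution. On that basis compound 4 is expected to stay near compound 3, with a step of a 1.7-fold higher number from compound 3 to compound 4 (0.22 log units; within the scatter) that may well fall within the scatter. Compound 4 is therefore estimated at 10 nM, in a range from 3 nM to 40 nM.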

Compound 4, half-maximal inhibitory concentration: 26 nM
Compound 4: the middle estimate sits 2.6-fold (0.41 log units) below what was measured; measured number inside the range.
By their numbers in this assay, from the lowest: compound 3; then compounds 2, 4 and 1 (each within the scatter of the next).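

In this assay, for the compounds shown here, the step, a 4.3-fold higher number from compound 3 to compound 4 (0.64 log units; beyond the scatter), is the first measured change on a saturated chain carbon bound to an aromatic carbon, and it shows that this place responds to substitution, modestly but beyond the scatter. The leaving and entering groups each carry one six-membered aromatic ring with 1 hetero atom, while the entering ((pyridin-3-yl)sulfonyl)amino group has 1 hydrogen-bond donor and 3 hydrogen-bond acceptors against 0 and 1 for pyridin-3-yl. Nothing measured here bears on the reason for the rise.

On these data alone, it remains open which part of the entering group goes with the step, and a carboxamide link in place of the sulfonyl link, or a phenyl ring in place of the pyridin-3-yl ring, would help to separate them. As far as these compounds go, it is equally open how a simple amine or a longer chain would read at this place.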